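This account rests on a few compounds, and the source may have more. Where it says the series, first, only, none or still open, it means among the compounds named here.

Measured so far in a physicochemical assay for acid dissociation:
- compound 1 `CN(Cc1ccc(N(C)C)cc1)Cc1cccc(CNc2ccnc3cc(Cl)ccc23)c1` gives 9.67
- compound 2 `COc1ccc(CN(C)Cc2ccc(CNc3ccnc4cc(Cl)ccc34)cc2)cc1` gives 9.7
- compound 3 `COc1ccc(CN(C)Cc2cccc(CNc3ccnc4cc(Cl)ccc34)c2)cc1` gives 9.67

All three numbers lie within the scatter of one another, so no order among them is read. Among the compounds with values here, the only structural change measured within the set is dimethylamino in place of methoxy on an aromatic carbon; the step it made was no change at the digits printed from compound 3 to compound 1 (within the scatter). Compound 2 and compound 3 share the same atoms joined differently, and the difference between the two cores is not broken down here.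

Compound 4 `CN(Cc1ccc(CNc2ccnc3cc(Cl)ccc23)cc1)Cc1ccc(N(C)C)cc1` has not yet been measured. From compound 2 it differs by dimethylamino in place of methoxy on an aromatic carbon, which is the same change as from compound 3 to compound 1, at the same place: on an aromatic carbon of a six-membered aromatic ring of carbon only, para to a large group. The step from compound 2 to compound 4 in this assay is therefore expected to be no change at the digits printed from compound 2 to compound 4 (within the scatter), because the earlier instance of the change gave no change at the digits printed from compound 3 to compound 1 (within the scatter). The expectation rests on compound 3 giving 9.67 and on compound 1 giving 9.67. Compound 4 is estimated at 9.7, with a range from 9.4 to 10.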

Compound 4, acid dissociation constant: 9.66
Beside the measured number, compound 4's estimate is 0.04 log units above it, within the range that was stated.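

In this assay, dimethylamino in place of methoxy on an aromatic carbon gives a number 0.04 log units lower from compound 2 to compound 4 (within the scatter), and the earlier instance gives no change at the digits printed from compound 3 to compound 1 (within the scatter), so neither step lies beyond the scatter. This shows that the absence of a readable step carries between the core of compound 3 and the core of compound 2 at this one place, on an aromatic carbon of a six-membered aromatic ring of carbon only, para to a large group, but two instances on two closely related cores make no general rule for other cores or other places. Nothing shown explains why the number holds across this change.

The compounds shown leave open what a carboxylic acid, a nitrile or trifluoromethyl at this same place would give in this assay, since only methoxy and dimethylamino stand there. They also leave open what a longer chain would give in place of the amine methyl shared by all four compounds.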